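Trifluoromethyl in place of methoxy on the outer ring

A few compounds are considered here, and "the series" means these few. Any claim that something is new, unique, unknown or untested is made for them only; others in the source may bear on it.

For the measured compounds named here, in a functional assay on HCT-116 cells (Homo sapiens) for antiproliferative activity, read by MTT assay, with a stated time of 72 h (a higher number here means a weaker inhibitor, a lower number a stronger inhibitor), compound 2 (`COc1ccc(-c2cccc(NC(=O)CCc3cccc4c3B(O)OC4)c2)cc1`) gives 160 nM and holds the lower of the two numbers so far, while compound 1 (`O=C(CCc1cccc2c1B(O)OC2)Nc1cccc(-c2cccc(Cl)c2)c1`) gives 350 nM in the same test. Compound 3 (`O=C(CCc1cccc2c1B(O)OC2)Nc1cccc(-c2ccc(C(F)(F)F)cc2)c1`) has trifluoromethyl in place of methoxy on an aromatic carbon, para to a large group (trifluoromethyl in place of methoxy on an aromatic carbon). Going by the values given here, the only measured step is a 2.2-fold lower number from compound 1 to compound 2 (0.34 log units; beyond the scatter) with 4-methoxyphenyl replacing 3-chlorophenyl, and it is modest and only a loose guide. Going by that step, a modest move to a higher number is expected in this assay for the new compound. The estimated change is a 1.9-fold higher number from compound 2 to compound 3 (0.27 log units; within the scatter) and no more than that is expected. Compound 3 is estimated at 300 nM with 120 nM to 750 nM as the expected range.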

Compound 3, half-maximal inhibitory concentration: 550 nM
Compound 3: middle estimate off by 1.8-fold (0.26 log units), on the low side, within the range that was stated.
By their numbers in this assay, from the lowest: compound 2; then compounds 1 and 3 (each within the scatter of the next).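

Replacing methoxy with trifluoromethyl on this aromatic carbon, para to a large group, raises the number clearly, with a 3.4-fold higher number from compound 2 to compound 3 (0.54 log units; beyond the scatter). Compound 3 does not separate from the chlorinated compound, with a 1.6-fold higher number from compound 1 to compound 3 (0.20 log units; within the scatter), so among these three outer rings only 4-methoxyphenyl stands apart. Nothing available here accounts for this difference.

Going by these compounds, whether the gain belongs to methoxy specifically remains open. A hydroxyl, an ethoxy or an amine on the same carbon would begin to test that.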